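A few compounds are considered here, and "the series" means these few. Any claim that something is new, unique, unknown or untested is made for them only; others in the source may bear on it.

Measured compounds:
- compound 1, `CNC(=O)CCCCCCCn1nc(-c2ccc3oc(N)nc3c2)c2c(N)ncnc21`: 10700 nM
- compound 2, `Nc1nc2cc(-c3nn(CCCCCCCCCC(=O)NO)c4ncnc(N)c34)ccc2o1`: 14100 nM
- compound 3, `Nc1ncnc2c1c(-c1cnc3[nH]ccc3c1)nn2CCCCCCC(=O)NO`: 14700 nM

All three were tested in a functional assay on SK-HEP1 cells (Homo sapiens) for inhibition, read by MTT assay, with a stated time of 72 h; a higher number here means a weaker inhibitor, a lower number a stronger inhibitor. Compound 3 has the highest of the three numbers, yet its gap to compound 2 and its gap to compound 1 both lie within the usual scatter, so nothing separates the three compounds on these figures.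

Compound 4, `Nc1ncnc2c1c(-c1cnc3[nH]ccc3c1)nn2CCCCCCCCCC(=O)NO`, has not yet been measured. It differs from compound 3 in one place: 3-(hydroxycarbamoyl)propyl in place of hydroxycarbamoyl on a saturated chain carbon, six bonds along the chain from an aromatic nitrogen

Among the compounds with values here, only one measured step bears on a lengthening of this chain. Between compound 1 and compound 2, where a 2-(hydroxycarbamoyl)ethyl replaces a methylcarbamoyl, the result is a 1.3-fold higher number from compound 1 to compound 2 (0.12 log units; within the scatter), a change that does not rise above the scatter. On that basis compound 4 is expected to stay close to compound 3, with no step beyond the scatter in this assay in either direction, the expected step being a 1.1-fold lower number from compound 3 to compound 4 (0.05 log units; within the scatter). The estimate for compound 4 is therefore 13000 nM, with an expected range from 5000 nM to 35000 nM.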

Compound 4, half-maximal inhibitory concentration: 23500 nM
Compound 4: middle estimate off by 1.8-fold (0.26 log units), on the low side; the measured number falls inside the stated range.
By their numbers in this assay, from the lowest: compounds 1, 2, 3 and 4 (each within the scatter of the next, the first and the last beyond it).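

In this assay, the lengthening of the chain ending in hydroxycarbamoyl, with the rest of the molecule unchanged, gives a 1.6-fold higher number from compound 3 to compound 4 (0.20 log units; within the scatter), so this position now has a direct reading of chain length alone, free of the change in end group that came with the earlier step, and that reading stays within the scatter. The aromatic group on the core can also be read on its own at this longer chain, and exchanging it gives a 1.7-fold higher number from compound 2 to compound 4 (0.22 log units; within the scatter), again no separation. Nothing available here accounts for these numbers.

The compounds shown leave open whether a still longer chain or a shorter one would move the number beyond the scatter. They also leave open what a carboxylic acid or a primary amine would do in place of hydroxycarbamoyl at the chain end.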